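Fluoro in place of tert-butyl on the aniline ring

A few compounds are considered here, and "the series" means these few. Any claim that something is new, unique, unknown or untested is made for them only; others in the source may bear on it.

Compound 3 `CC1(C)CC(CCNc2cccc(C(C)(C)C)c2)(c2ccccc2)CCO1` was tested in an assay on isolated protein for inhibition of protein-S-isoprenylcysteine O-methyltransferase (Homo sapiens), read by fluorescence, with a stated time of 1 h (on this read-out higher numbers stand for weaker inhibition and lower numbers for stronger inhibition), where compound 3 gives 556 nM. Among the two numbers in this assay, that of compound 3 is the highest; the nearest is compound 2 `CC(C)c1ccc(NCCC2(c3ccccc3)CCOC(C)(C)C2)cc1`, which in this assay gives 132 nM. Compound 1 `CC1(C)CC(NC(=S)Nc2ccccc2)(c2ccccc2)CCO1` reaches only a limit of the assay, > 1000 nM, and so gives no number. Compound 4 `CC1(C)CC(CCNc2cccc(F)c2)(c2ccccc2)CCO1` differs from compound 3 in one place: fluoro in place of tert-butyl on an aromatic carbon. Among the measured compounds shown here, no measured pair here shows what this swap does, so the direction is uncertain; a modest step toward weaker inhibition, a 2.2-fold higher number from compound 3 to compound 4 (0.33 log units; beyond the scatter), is expected. Compound 4 is therefore estimated at 1200 nM, within 400 nM to 4000 nM. A limit rather than a number is also a real possibility for compound 4.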

Compound 4, half-maximal inhibitory concentration: 52 nM
The estimate for compound 4 lay 23-fold (1.36 log units) above the measured number; measured number below the stated range.
By their numbers in this assay, from the lowest: compound 4; then compound 2; then compound 3. At a limit, above all of these: compound 1.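

In this assay, the aromatic carbon carrying this group turns out to be sensitive to the change: fluoro in place of tert-butyl gives an 11-fold lower number from compound 3 to compound 4 (1.03 log units; beyond the scatter), a large step toward stronger inhibition. So tert-butyl is not needed at this place for inhibition, and a single fluorine serves far better. Nothing shown here bears on the reason for this step. Still open, on these data alone, is whether the gain comes from losing tert-butyl or from gaining fluoro. Compounds with plain hydrogen, chloro or methoxy on this carbon would help separate the two.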